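A partial agonist series with a shortened side chain

The source may hold more compounds than are shown below. What is called first, only, known or untested is meant among the compounds shown, and "the series" means these compounds.

Three closely related amides have been measured in an ADME assay on HEK293 cells for agonist activity at metabotropic glutamate receptor 5 (Rattus norvegicus), read by fluorescence and calcium flux; on this read-out lower numbers stand for smaller maximal responses and higher numbers for larger maximal responses. Compound 1 `C[C@@H](NC(=O)c1ccc(C#Cc2ncccc2F)cn1)C(C)(C)O` gives 29.2%. Compound 2 `C[C@@H](NC(=O)c1ccc(C#Cc2cccc(F)c2)nc1)C(C)(C)O` gives 26.6%. Compound 3 `C[C@@H](NC(=O)c1ccc(C#Cc2cccc(F)c2)cn1)C(C)(C)C` gives 31.2%. On these numbers compound 3 reads the highest of the three, but its distance to compound 1 and to compound 2 both stay within the usual scatter of repeated measurements, so no ranking among them can be claimed, and all three sit in the same low band of maximal response.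

Compound 4 `CC(C)[C@@H](C)NC(=O)c1ccc(C#Cc2cccc(F)c2)cn1` is not yet measured. It differs from compound 3 in one place: hydrogen in place of methyl on a saturated chain carbon bound to three saturated chain carbons. The change is small and touches only the saturated chain on the amide side, away from the aromatic part that compounds 1, 2 and 3 vary among themselves without any difference beyond the scatter.

Because compound 3 gives 31.2% and the two neighbours stay near it, compound 4 is expected to remain in the same band, with the step from compound 3 estimated as a number 2.2 percentage points lower from compound 3 to compound 4 (within the scatter), that is, none beyond the scatter. Compound 4 is estimated at 29%, in the range 18% to 42%.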

Compound 4, largest response reached (reported as efficacy), in percent of the reference or control that the assay uses: 22.5%
Compound 4: middle estimate off by 6.5 percentage points, on the high side; the measured number falls inside the stated range.
By their numbers in this assay, from the lowest: compounds 4, 2, 1 and 3 (each within the scatter of the next).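

For the compounds shown here, this is the first pair that differs in one place only, so it gives the first direct reading of the saturated chain on the amide side. In this assay, hydrogen in place of methyl on a saturated chain carbon bound to three saturated chain carbons, which turns tert-butyl into isopropyl, gives a step (a number 8.7 percentage points lower from compound 3 to compound 4 (within the scatter)), so this single methyl cannot be said to change the maximal response, although the step is a large one for a within-scatter difference and a small real effect cannot be excluded on one pair. Nothing available bears on why the step has this size.

The pair leaves open whether the same replacement would read the same way on the hydroxyl-bearing chain of compound 1 and compound 2, or with the other aromatic ends those compounds carry. It also leaves open how far this position can be varied, since an amine, a carboxylic acid or a longer chain such as n-butyl at this carbon could move the response out of the band that these four compounds occupy.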